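The source may report more compounds than this note shows. Statements on the series, on what has been measured and on what is new or still open speak of the compounds shown alone.

Measured in an assay on isolated protein for inhibition of Amine oxidase [flavin-containing] A (Rattus norvegicus); on this read-out lower numbers stand for stronger inhibition and higher numbers for weaker inhibition:
Compound 1, `c1ccc(CNCc2cn(Cc3ccccc3)c3ccccc23)cc1`: 245000 nM
Compound 2, `C#CCN(C)Cc1cc2ccccc2n1C`: 0.302 nM

Of the two numbers, compound 1 stands highest, at 245000 nM, and is therefore by far the weaker inhibitor; compound 2 sits at 0.302 nM, a gap well beyond the usual scatter. For the measured compounds named here, compound 2 differs from compound 1 in more than one place, so its value only shows how wide the spread in this set can be and gives no single-change step to lean on.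

Compound 3 is `CC(C)NCc1cn(Cc2ccccc2)c2ccccc12`. It differs from compound 1 in one place: isopropyl in place of benzyl on an amine nitrogen. Going by the values given here, no measured pair shows what this exchange does, so the expectation rests on compound 1 alone. The part that leaves and the part that enters are both plain carbon groups with no donors or acceptors, and nothing measured points in either direction, so the step of a 1.2-fold lower number from compound 1 to compound 3 (0.09 log units; within the scatter) is expected to stay within the scatter. Compound 3 is thus expected to give about 200000 nM, with a range from 40000 nM to 1000000 nM.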

Compound 3, inhibition constant: 132000 nM
For compound 3 the middle estimate is 1.5-fold (0.18 log units) above the measured one, and the stated range covers the measured number.
By their numbers in this assay, from the lowest: compound 2; then compounds 3 and 1 (each within the scatter of the next).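

In this assay, for the compounds shown here, isopropyl in place of benzyl on the amine nitrogen gives a 1.9-fold lower number from compound 1 to compound 3 (0.27 log units; within the scatter), the first single-change step in this set. For this pair, then, the six-membered aromatic ring of the benzyl group can be given up without a shift that stands out from the scatter, and the two groups cannot be told apart by this read-out. The result applies only to this one exchange on the core of compound 1, and nothing on hand explains why the two groups read alike.

Benzyl and isopropyl are both plain carbon groups with no hydrogen-bond donors or acceptors, so the compounds shown leave open what a hydroxyethyl group or a carboxylic acid would do on this amine nitrogen. Also open, on these data alone, is whether a group as short as methyl, or a longer chain such as hexyl, would stay within the scatter of compound 1 in the same way.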